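Positional isomer of compound 3: expected cytotoxicity

A few compounds are considered here, and "the series" means these few. Any claim that something is new, unique, unknown or untested is made for them only; others in the source may bear on it.

For the measured compounds named here, compound 3 `COc1cccc(C=O)c1OCc1cn(CCCOc2ccc3ccc(=O)oc3c2)nn1` gives 13300 nM in a functional assay on HT-29 cells (Homo sapiens) for cytotoxicity, read by MTT assay, with a stated time of 24 h (a lower number here means a stronger inhibitor, a higher number a weaker inhibitor), the lowest of the three numbers so far. Compound 1 `C#CCOc1ccc(Br)cc1/C=N/Cc1ccc(S(N)(=O)=O)cc1` gives 45700 nM and compound 2 `O=Cc1ccc(OCc2cn(CCCOc3ccc4ccc(=O)oc4c3)nn2)cc1` gives 100000 nM. Going by the values given here, the only single-point step measured, a 7.5-fold lower number from compound 2 to compound 3 (0.88 log units; beyond the scatter), bears directly on compound 4 `COc1cc(C=O)ccc1OCc1cn(CCCOc2ccc3ccc(=O)oc3c2)nn1`, which carries 4-formyl-2-methoxyphenyl in place of 2-formyl-6-methoxyphenyl on an oxygen on a saturated carbon; the two have the same atoms, joined differently. Compound 4 keeps the 4-formylphenyl arrangement of compound 2 and the methoxy of compound 3, so it sits structurally between them. Since the step from compound 2 to compound 3 was modest but beyond the scatter, a step back toward weaker inhibition is expected for compound 4, yet smaller than that full gap. Compound 4 is expected to give 40000 nM (range 13000 nM to 120000 nM), a step of a 3.0-fold higher number from compound 3 to compound 4 (0.48 log units; beyond the scatter).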

Compound 4, half-maximal inhibitory concentration: 65400 nM
Beside the measured number, compound 4's estimate is 1.6-fold (0.21 log units) below it, and the stated range covers the measured number.
By their numbers in this assay, from the lowest: compound 3; then compounds 1, 4 and 2 (each within the scatter of the next, the first and the last beyond it).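

In this assay the two isomers are separated (a 4.9-fold higher number from compound 3 to compound 4 (0.69 log units; beyond the scatter)), so the arrangement of formyl and methoxy on the ring matters, not the presence of the methoxy alone. Methoxy on the 4-formylphenyl arrangement gives no difference beyond the scatter (a 1.5-fold lower number from compound 2 to compound 4 (0.18 log units; within the scatter)). No measurement at hand accounts for the gap between the isomers. Open, as far as these compounds go, is whether the lower number of compound 3 needs both groups of the 2-formyl-6-methoxyphenyl ring. A 2-formylphenyl group without methoxy, or a carboxylic acid or an amine in place of the formyl, would test this.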